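Six-thioether purine ribosides: aryl versus benzyl on sulfur

The source may report more compounds than this note shows. Statements on the series, on what has been measured and on what is new or still open speak of the compounds shown alone.

Three compounds carry the same ribose-bearing purine core or a close relative of it. Compound 1 `OC[C@H]1O[C@@H](n2cnc3c(NCc4ccco4)ncnc32)[C@H](O)[C@@H]1O` holds a furanylmethylamine on the core and in an assay on isolated protein for binding affinity to Equilibrative nucleoside transporter 1 (Homo sapiens) (on this read-out higher numbers stand for weaker inhibition and lower numbers for stronger inhibition), compound 1 gives 36300 nM. Compound 2 `Nc1nc(SCc2cccc(Br)c2)c2ncn([C@@H]3O[C@H](CO)[C@@H](O)[C@H]3O)c2n1` carries an amino group together with a 3-bromobenzyl on a sulfur, and in this assay compound 2 gives 2880 nM. Compound 3 `CCCSc1nc(N)nc2c1ncn2CC(C)C` lacks the sugar and bears a short alkyl chain on the sulfur; in this assay compound 3 gives 63100 nM. Compound 2 has the lowest number of the three, and its distances to compound 1 and to compound 3 both lie beyond the scatter, so it is the strongest inhibitor of this set.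

Compound 4 `CC(=O)c1cc(Cl)ccc1Sc1nc(N)nc2c1ncn2[C@@H]1O[C@H](CO)[C@@H](O)[C@H]1O` keeps the core, the sugar and the amino group of compound 2 and changes only the sulfur substituent: 2-acetyl-4-chlorophenyl in place of 3-bromobenzyl on a sulfur. Among the compounds with values here, no pair of measured compounds differs in this way, so the direction of the step cannot be read from the data. A step from compound 2 to compound 4 of no more than the scatter is expected, in either direction, with a wide range. Compound 4 is estimated at 3000 nM, between 600 nM and 15000 nM, which corresponds to an expected step of a 1.0-fold higher number from compound 2 to compound 4 (0.02 log units; within the scatter).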

Compound 4, half-maximal inhibitory concentration: 14500 nM
The estimate for compound 4 lay 4.8-fold (0.68 log units) below the measured number, within the range that was stated.
By their numbers in this assay, from the lowest: compound 2; then compound 4; then compounds 1 and 3 (each within the scatter of the next).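

In this assay the swap of 3-bromobenzyl for 2-acetyl-4-chlorophenyl on the sulfur gives a 5.0-fold higher number from compound 2 to compound 4 (0.70 log units; beyond the scatter) with the core, the sugar and the amino group held fixed. Within the data shown here, this is the first reading of a change at this sulfur alone, since the earlier compounds differ from one another in more than one place, and it shows that the sulfur substituent by itself moves the number beyond the scatter, with the 3-bromobenzyl compound on the lower side. No measurement in hand accounts for the size or direction of this step.

From the compounds shown here alone, the step bundles several changes at once: the benzyl becomes a directly attached aromatic ring, bromine gives way to chlorine, and an acetyl group with its carbonyl enters, so the share of each stays open. Going by these compounds, an unsubstituted benzyl or a plain phenyl on the same sulfur would begin to separate these parts, and whether an amine or a carboxylic acid on that ring is compatible with the lower number also remains open.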